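Coumarin amide series: benzyl amide without methoxy

The compounds below may be only part of what the source reports. "The series", "measured", "known", "first", "only" and "open" are said of these compounds alone.

Measured so far:
compound 1 `COc1ccc(CNC(=O)c2cc3cc(OC)c(OCCCOc4no[n+]([O-])c4S(=O)(=O)c4ccccc4)cc3oc2=O)cc1`: 780 nM
compound 2 `COc1ccc(NC(=O)c2cc3cc(OC)c(OCCCOc4no[n+]([O-])c4S(=O)(=O)c4ccccc4)cc3oc2=O)cc1`: 730 nM

In a functional assay on MDA-MB-231 cells (Homo sapiens) for inhibition, read by MTT assay, with a stated time of 48 h (a lower number here means a stronger inhibitor, a higher number a weaker inhibitor), compound 2 gives 730 nM and compound 1 gives 780 nM; the two sit within the scatter of each other, as the step of a 1.1-fold lower number from compound 1 to compound 2 (0.03 log units; within the scatter) shows. Compound 3 `COc1cc2cc(C(=O)NCc3ccccc3)c(=O)oc2cc1OCCCOc1no[n+]([O-])c1S(=O)(=O)c1ccccc1` carries the change (benzyl in place of 4-methoxyphenyl on an amide-type nitrogen). For the measured compounds named here, only the step from compound 1 to compound 2 bears on this, and it was flat; nothing measured separates the methoxy-bearing from the bare benzyl amide. No step beyond the scatter is therefore expected in this assay, the estimated change being a 1.1-fold higher number from compound 2 to compound 3 (0.04 log units; within the scatter). Compound 3 is estimated at 800 nM, with a range of 400 nM to 1600 nM.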

Compound 3, half-maximal inhibitory concentration: 1060 nM
The estimate for compound 3 lay 1.3-fold (0.12 log units) below the measured number, within the range that was stated.
By their numbers in this assay, from the lowest: compounds 2, 1 and 3 (each within the scatter of the next).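

In this assay, hydrogen in place of methoxy on an aromatic carbon of the benzyl amide gives a 1.4-fold higher number from compound 1 to compound 3 (0.13 log units; within the scatter), and benzyl in place of 4-methoxyphenyl gives a 1.5-fold higher number from compound 2 to compound 3 (0.16 log units; within the scatter). The loss of the methoxy group is now tested directly, and neither step leaves the scatter, so these three compounds show no separation at this amide nitrogen. Nothing available explains these small steps. As far as these compounds go, whether an amine or a carboxylic acid on the aromatic ring, or a longer chain such as phenethyl in place of benzyl, would give a step beyond the scatter stays open.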